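Lengthening the methoxy chain of compound 3

This account rests on a few compounds, and the source may have more. Where it says the series, first, only, none or still open, it means among the compounds named here.

In a physicochemical assay for solubility, in phosphate buffer, measured as kinetic solubility, at pH 7.4, tested at 250 uM (a higher number here means a more soluble compound, a lower number a less soluble compound), compound 3 (`COCCNc1ccc(C(=O)O)cc1S(=O)(=O)N(C)C`) gives 237000 nM, the higher of the two exact numbers, while compound 1 (`CCCCCCCCNc1ccc(C(=O)O)cc1S(=O)(=O)N(C)C`) gives 52000 nM. Compound 2 (`CN(C)S(=O)(=O)c1cc(C(=O)O)ccc1NCCC(C)(C)C`) reads > 250000 nM, which is a limit of the assay. Compound 4 (`COCCCCCCNc1ccc(C(=O)O)cc1S(=O)(=O)N(C)C`) differs from compound 3 by 4-methoxybutyl in place of methoxy on a saturated chain carbon, two bonds along the chain from a nitrogen on an aromatic ring. For the measured compounds named here, two measured steps bear on this change: methoxy in place of hexyl gave a 4.6-fold higher number from compound 1 to compound 3 (0.66 log units; beyond the scatter), and tert-butyl in place of hexyl gave an at least 4.8-fold higher number from compound 1 to compound 2 (0.68 log units; beyond the scatter). The entering 4-methoxybutyl resembles the hexyl of compound 1 more than methoxy does, so part of the first step should reverse. The expected change is a 2.2-fold lower number from compound 3 to compound 4 (0.33 log units; beyond the scatter). Compound 4 is estimated at 110000 nM, with an expected range of 55000 nM to 230000 nM.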

Compound 4, solubility: > 250000 nM
Compound 4 gave a limit, no number; the forecaster's own chance of this, stated with the estimate: 10%; middle value at least 2.2-fold (0.35 log units) away from the limit.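

Compound 4 gives a limit, not a number, and its step against compound 2, also a limit, cannot be read: the limit of > 250000 nM in this assay, at which 2 of the 4 values shown sit 4-Methoxybutyl in place of methoxy gives an at least 1.0-fold higher number from compound 3 to compound 4 (0.02 log units; that floor lies within the scatter), which sets no order between the two compounds, while methoxy in place of ethyl, six bonds along the chain from a nitrogen on an aromatic ring, gives an at least 4.8-fold higher number from compound 1 to compound 4 (0.68 log units; beyond the scatter). A long chain at this position therefore need not bring the number in this assay down to that of compound 1, provided it carries the methoxy.

On these data alone, how far compound 4 lies past its limit remains open. So does whether an amine or a carboxylic acid in place of that methoxy would give the same reading.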